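Adding a Chloro Group to an Inactive Thiazolidinone Pair

The source may hold more compounds than are shown below. What is called first, only, known or untested is meant among the compounds shown, and "the series" means these compounds.

Measured compounds:
Compound 1, `O=C1NC(=O)/C(=C/c2cc(Cl)ccc2OCN2C(=O)c3ccccc3C2=O)S1`: > 100000 nM
Compound 2, `O=C1NC(=S)S/C1=C\c1ccccc1OCN1C(=O)c2ccccc2C1=O`: > 100000 nM

Both compounds were tested in an assay on isolated protein for inhibition of Alpha glucosidase (Homo sapiens), read by spectrophotometry, with stated times of 15 min and 30 min; on this read-out lower numbers stand for stronger inhibition and higher numbers for weaker inhibition. For compound 1 the result > 100000 nM is a limit of the assay, not a number. For compound 2 the result > 100000 nM is likewise a limit, not a number. Compound 2 therefore stands at the edge of what this assay can report, and nothing separates it from compound 1, since (the limit of > 100000 nM in this assay, at which 2 of the 2 values shown sit).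

Compound 3, `O=C1NC(=S)S/C1=C\c1cc(Cl)ccc1OCN1C(=O)c2ccccc2C1=O`, has not yet been measured in this assay. It differs from compound 2 in one place: chloro in place of hydrogen on an aromatic carbon. Compound 1 already carries this chloro group on the same kind of aromatic carbon and also sits at the limit, so no step beyond the scatter is expected, and compound 3 is expected to remain weak. The expected step from compound 2 to compound 3 is a step that the limit leaves unreadable from compound 2 to compound 3. Compound 3 is estimated at 150000 nM, within 50000 nM to 500000 nM.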

Compound 3, half-maximal inhibitory concentration: 34800 nM
The estimate for compound 3 lay 4.3-fold (0.63 log units) above the measured number; the measured number lies below the stated range.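

In this assay, among these compounds, chloro in place of hydrogen on this aromatic carbon brings the first readable number of the series, with an at least 2.8-fold lower number from compound 2 to compound 3 (0.45 log units; beyond the scatter). Chloro alone is not enough, since compound 1 carries it as well, and replacing its group of 8 heavy atoms holding 1 sulfur with the one holding 2 sulfur gives an at least 2.8-fold lower number from compound 1 to compound 3 (0.45 log units; beyond the scatter), so among these compounds a readable number appears only where chloro and the group holding 2 sulfur occur together. Both steps are minimum sizes rather than exact ones because each starts from a limit: the limit of > 100000 nM in this assay, at which 2 of the 3 values shown sit.

The compounds shown leave open whether another group at this place, such as bromo, methoxy or an amine, would give a lower number than chloro. They also leave open whether chloro on a different carbon of the same ring would give any readable number at all.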